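Swapping furan for thiophene on an adenosine A2b binder

This account rests on a few compounds, and the source may have more. Where it says the series, first, only, none or still open, it means among the compounds named here.

Four compounds share one core, a six-membered non-aromatic ring with 2 nitrogen, and differ in two places. Compound 1 `CCN(CC)C(=O)C1=C(C)NC(=O)NC1c1ccoc1` gives 12% in an assay on membranes from HEK293 cells for displacement of a labelled ligand from adenosine receptor A2b (Homo sapiens), read by scintillation counting, with a stated time of 30 min, tested at 1 uM; on this read-out lower numbers stand for less inhibition and higher numbers for more inhibition at the one concentration tested (going by the name of the read-out). Compound 2 `CCN(CC)C(=O)C1=C(C)NC(=O)NC1c1cccs1` carries the change thiophen-2-yl in place of furan-3-yl on a saturated ring carbon and gives 22%; the step of a number 10 percentage points higher from compound 1 to compound 2 (within the scatter). Compound 3 `CCSC(=O)C1=C(C)NC(=O)NC1c1ccoc1` carries the change ethylsulfanyl in place of diethylamino on a carbonyl carbon and gives 1%, the step being a number 11 percentage points lower from compound 1 to compound 3 (beyond the scatter). Compound 4 `CCSC(=O)C1=C(C)NC(=O)NC1c1cccs1` is not yet measured; it differs from compound 3 by thiophen-2-yl in place of furan-3-yl on a saturated ring carbon. This is the same kind of change as that from compound 1 to compound 2, though the surroundings differ in their printed words: in compound 1 the saturated ring carbon is next to the ring atom that bears a group of 7 heavy atoms, in compound 3 next to the ring atom that bears a (ethylsulfanyl)carbonyl group (5 heavy atoms). Because a number 10 percentage points higher from compound 1 to compound 2 (within the scatter) stayed within the scatter, compound 4 is expected to move by only a number 7 percentage points higher from compound 3 to compound 4 (within the scatter) from compound 3. Compound 4 is therefore estimated at 8%, within 0% to 22%.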

Compound 4, a percentage reported as inhibition, at one concentration (the size of the read-out at that concentration, not a potency): 1%
Beside the measured number, compound 4's estimate is 7 percentage points above it; measured number inside the range.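

In this assay, thiophen-2-yl in place of furan-3-yl with ethylsulfanyl on the carbonyl carbon gives no change at the digits printed from compound 3 to compound 4 (within the scatter), and this agrees with the same swap made with diethylamino there: the same change on two cores in this assay, a number 10 percentage points higher (within the scatter) from compound 1 to compound 2 and no change at the digits printed (within the scatter) from compound 3 to compound 4, 10 percentage points apart, within the scatter of two such steps. Ethylsulfanyl in place of diethylamino, now with thiophen-2-yl on the saturated ring carbon, gives a number 21 percentage points lower from compound 2 to compound 4 (beyond the scatter), which likewise agrees with the earlier step: the same change on two cores in this assay, a number 11 percentage points lower (beyond the scatter) from compound 1 to compound 3 and a number 21 percentage points lower (beyond the scatter) from compound 2 to compound 4, 10 percentage points apart, within the scatter of two such steps. So within these four compounds, each change reads alike in both settings, but that rests on only two pairs per change at a single concentration, and it does not show that the ring swap moves the result beyond the scatter in either setting, nor that the pattern would hold on other cores.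

As far as these compounds go, it remains open how other groups on the carbonyl carbon, such as a carboxylic acid or a piperidine amide, would read in this test. From the compounds shown here alone, it is equally open whether a phenyl ring on the saturated ring carbon would follow the same pattern.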